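The source may report more compounds than this note shows. Statements on the series, on what has been measured and on what is new or still open speak of the compounds shown alone.

Compound 1 `CCCC(=O)OCSc1ccccc1C(=O)NCCCCC(N)=O` gives 51.7 uM in the measurements so far
Compound 2 `CCCC(=O)OCSc1ccccc1C(=O)NCC(=O)NCc1ccccc1` gives 29.3 uM in the measurements so far

Both numbers come from an ADME assay on CEM-SS cells (Homo sapiens) for cytotoxicity, read by XTT assay, with a stated time of 6 days (a higher number here means that more compound is tolerated, a lower number that less compound is tolerated), and are all that is known in this small set. Compound 2 stands at 29.3 uM on this read-out and compound 1 at 51.7 uM on the same one, and these two values lie within the usual scatter of each other, so neither can be ranked over the other.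

Compound 3 `CCCC(=O)OCSc1ccccc1C(=O)NCC(=O)NCC(=O)OC` has not yet been measured. It departs from compound 2 by a single change, methoxycarbonyl in place of phenyl on a saturated chain carbon bound to an amide-type nitrogen in all, which is methoxycarbonyl in place of phenyl on a saturated chain carbon bound to an amide-type nitrogen. Within the data shown here, no measured pair differing in one place exists, so the data give no direct guide to the effect of this change. With compound 2 at 29.3 uM as the starting point, no step beyond the scatter is expected, and any shift is expected to be slightly upward. The expected change is a 1.4-fold higher number from compound 2 to compound 3 (0.14 log units; within the scatter) and would stay within the scatter. In this assay the estimated value for compound 3 is 40 uM with an expected range from 18 uM to 90 uM as its bounds.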

Compound 3, half-maximal toxic concentration: > 100 uM
Compound 3: only a limit was reported; the forecaster's own chance of this, stated with the estimate: 12%; at least 2.5-fold (0.39 log units) between middle value and limit.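

In this assay, methoxycarbonyl in place of phenyl on a saturated chain carbon bound to an amide-type nitrogen gives an at least 3.4-fold higher number from compound 2 to compound 3 (0.53 log units; beyond the scatter). Among these compounds, this is the first single change here that can be read beyond the scatter, and it shows that this place bears on the read-out, which the close values of compound 1 and compound 2 could not show. The change of 3-carbamoylpropyl to ((methoxycarbonyl)methyl)carbamoyl gives an at least 1.9-fold higher number from compound 1 to compound 3 (0.28 log units; that floor lies within the scatter), so the floor of this step does not yet separate the two compounds, and the value for compound 3 is only a limit, which leaves the full size of both steps unknown: the limit of > 100 uM in this assay, at which 1 of the 3 values shown sits.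

The compounds shown do not tell whether the step comes from the loss of the phenyl ring or from the entry of the methoxycarbonyl group, since both happen in one change. A carboxylic acid or a plain methyl group at the same place, or a cyclohexyl group in the position of the phenyl, would be needed to pull those two apart.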